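From iodo to butyl: compound 1 to compound 4

The source may hold more compounds than are shown below. What is called first, only, known or untested is meant among the compounds shown, and "the series" means these compounds.

In an ADME assay on Vero cells (Chlorocebus sabaeus) for cytotoxicity, read by resazurin assay, with a stated time of 72 h (on this read-out higher numbers stand for lower toxicity in this test and lower numbers for higher toxicity in this test), compound 1 `O=C(/C=C/c1ccc([N+](=O)[O-])o1)c1ccc(I)cc1` gives > 100000 nM, which is a limit of the assay and not a number. Compound 2 `CC(C)(C)c1ccc(C(=O)/C=C/c2ccc([N+](=O)[O-])o2)cc1` gives > 100000 nM, likewise a limit. Compound 3 `Cc1ccccc1C(=O)/C=C/c1ccc([N+](=O)[O-])o1` gives a true number, 41300 nM. Compound 1 thus stands at the limit of > 100000 nM in this assay, at which 2 of the 3 values shown sit.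

Compound 4 `CCCCc1ccc(C(=O)/C=C/c2ccc([N+](=O)[O-])o2)cc1` carries butyl in place of iodo on an aromatic carbon. Within the data shown here, only one measured step bears on this change, and it also replaces iodo with an alkyl group: a step that the two limits leave unreadable from compound 1 to compound 2. No size can be taken from that step, though compound 2 still reaches the limit of > 100000 nM. In this assay no step beyond the scatter is therefore expected, and another limit is quite possible. The estimated step is an at least 1.2-fold lower number from compound 1 to compound 4 (0.09 log units; that floor lies within the scatter), and its size remains uncertain while compound 1 has no number. For compound 4 the expected value is 80000 nM, with an estimated range of 30000 nM to 150000 nM.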

Compound 4, half-maximal cytotoxic concentration: 75700 nM
For compound 4 the middle estimate is 1.1-fold (0.02 log units) above the measured one, within the range that was stated.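

In this assay, among these compounds, compound 4 is the first compound with a group on this aromatic carbon, para to a large group, to give a true number. Compound 1 and compound 2 each give a limit and not a number: the limit of > 100000 nM in this assay, at which 2 of the 4 values shown sit. Butyl in place of iodo gives an at least 1.3-fold lower number from compound 1 to compound 4 (0.12 log units; that floor lies within the scatter), and butyl in place of tert-butyl gives an at least 1.3-fold lower number from compound 2 to compound 4 (0.12 log units; that floor lies within the scatter), so only floors can be read, neither reaches beyond the scatter, and the true size of each step stays unknown.

The compounds shown leave open how far the true values of compound 1 and compound 2 lie from that of compound 4. They also leave open whether a longer chain, an amine or a carboxylic acid at this place would lower the number in this assay beyond the scatter.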